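The source may report more compounds than this note shows. Statements on the series, on what has been measured and on what is new or still open speak of the compounds shown alone.

In a functional assay on CWR22R cells (Homo sapiens) for antiproliferative activity, read by propidium iodide staining, with a stated time of 96 h (on this read-out lower numbers stand for stronger inhibition and higher numbers for weaker inhibition), three compounds have been measured so far. Compound 1 `CC(O)(CSc1cccc(S(F)(F)(F)(F)F)c1)C(=O)Nc1ccc(C#N)c(C(F)(F)F)c1` gives 20400 nM, compound 2 `CC(O)(CS(=O)(=O)c1ccc(S(F)(F)(F)(F)F)cc1)C(=O)Nc1ccc(S(F)(F)(F)(F)F)cc1` gives 17300 nM, and compound 3 `CC(O)(CS(=O)(=O)c1ccc(F)cc1)C(=O)Nc1ccc(S(F)(F)(F)(F)F)cc1` gives 20600 nM, so compound 3 stands level with the other two within the usual scatter. Compound 4 `CC(O)(CS(=O)(=O)c1cccc(OC(F)(F)F)c1)C(=O)Nc1ccc(S(F)(F)(F)(F)F)cc1` differs from compound 3 in one place: 3-(trifluoromethoxy)phenyl in place of 4-fluorophenyl on a sulfonyl sulfur. For the measured compounds named here, the only measured step that alters a group on this same sulfonyl-bound ring is a 1.2-fold higher number from compound 2 to compound 3 (0.08 log units; within the scatter), and it stayed within the scatter. No step beyond the scatter is therefore expected in this assay. The expected change is a 1.1-fold lower number from compound 3 to compound 4 (0.06 log units; within the scatter). For compound 4 the estimated value is 18000 nM, with an expected range from 8000 nM to 40000 nM.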

Compound 4, half-maximal inhibitory concentration: 22400 nM
For compound 4 the middle estimate is 1.2-fold (0.09 log units) below the measured one, and the stated range covers the measured number.
By their numbers in this assay, from the lowest: compounds 2, 1, 3 and 4 (each within the scatter of the next).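

In this assay, putting 3-(trifluoromethoxy)phenyl in place of 4-fluorophenyl on a sulfonyl sulfur gives a 1.1-fold higher number from compound 3 to compound 4 (0.04 log units; within the scatter), and this stays within the scatter. For the compounds shown here, the earlier step changed only one group on the ring, whereas here a ring group of 11 heavy atoms, carrying a hydrogen-bond acceptor, replaces one of 7 with no readable change in the number. No supporting measurement bears on this result.

The compounds shown leave open whether any group on this ring can move the number beyond the scatter. An amine or a carboxylic acid there remains an untested case in what is shown.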